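Trifluoromethyl for methyl on the benzyl arm of an indolyl-quinoxaline oxime ether

The source may report more compounds than this note shows. Statements on the series, on what has been measured and on what is new or still open speak of the compounds shown alone.

Measured compounds:
- compound 1, `Cc1ccc(CO/N=C2/C(c3c[nH]c4ccccc34)=Nc3ccccc32)cc1`, 22800 nM
- compound 2, `Cc1ccc(CO/N=C2/C(c3c[nH]c4ccc(Br)cc34)=Nc3ccc(Br)cc32)cc1`, 31200 nM
- compound 3, `FC(F)(F)c1ccc(CO/N=C2/C(c3c[nH]c4ccccc34)=Nc3ccccc32)cc1`, 30600 nM

Of the compounds shown here, three have been tested in a functional assay on MGC-803 cells (Homo sapiens) for cytotoxicity, read by MTT assay, with a stated time of 2 days; a lower number here means a stronger inhibitor, a higher number a weaker inhibitor. Compound 1, `Cc1ccc(CO/N=C2/C(c3c[nH]c4ccccc34)=Nc3ccccc32)cc1`, gives 22800 nM. Compound 3, `FC(F)(F)c1ccc(CO/N=C2/C(c3c[nH]c4ccccc34)=Nc3ccccc32)cc1`, gives 30600 nM in this assay. Compound 2, `Cc1ccc(CO/N=C2/C(c3c[nH]c4ccc(Br)cc34)=Nc3ccc(Br)cc32)cc1`, gives 31200 nM. All three numbers lie close together, and none of the differences between them goes beyond the usual scatter of repeated measurements.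

Compound 3 is compound 1 with one change, (trifluoromethyl in place of methyl on an aromatic carbon). That change made the step of a 1.3-fold higher number from compound 1 to compound 3 (0.13 log units; within the scatter) in this assay, a step small enough to count as no real change.

Compound 4, `FC(F)(F)c1ccc(CO/N=C2/C(c3c[nH]c4ccc(Br)cc34)=Nc3ccc(Br)cc32)cc1`, has not yet been measured. It stands to compound 2 as compound 3 stands to compound 1: the change from compound 2 to compound 4 is trifluoromethyl in place of methyl on an aromatic carbon, placed in the same surroundings as in the earlier pair. The difference between the core of compound 2 and the core of compound 1 is not broken down here.

Because the earlier step of a 1.3-fold higher number from compound 1 to compound 3 (0.13 log units; within the scatter) was within the scatter, the expected step from compound 2 to compound 4 is estimated to be of a similar size, a 1.3-fold higher number from compound 2 to compound 4 (0.11 log units; within the scatter). The value of compound 4 in this assay is therefore expected to be about 40000 nM, with a plausible range from 18000 nM to 90000 nM.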

Compound 4, half-maximal inhibitory concentration: 11100 nM
Beside the measured number, compound 4's estimate is 3.6-fold (0.56 log units) above it; the measured number lies below the stated range.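

In this assay, going from 4-methylbenzyl to 4-(trifluoromethyl)benzyl on the second core gives a 2.8-fold lower number from compound 2 to compound 4 (0.45 log units; beyond the scatter), a modest move towards a stronger inhibitor. The same change therefore does not behave alike on the two cores, and the two steps lie further apart than scatter alone would explain: the same change on two cores in this assay, a 1.3-fold higher number (0.13 log units; within the scatter) from compound 1 to compound 3 and a 2.8-fold lower number (0.45 log units; beyond the scatter) from compound 2 to compound 4, 3.8-fold (0.58 log units) apart, beyond the scatter of two such steps. This shows that in this series the step seen on the core of compound 1 could not simply be carried over to the core of compound 2, but one pair on each core does not show why the two differ, nor whether the lower number would hold on any further core.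

Going by these compounds, it remains open whether a single bromine on the core, rather than both, would be enough to turn the step around, and whether chlorine in place of bromine would do the same. Also open, on these data alone, is how a methoxy group, or a plain hydrogen, in place of the methyl would behave on each of the two cores.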